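Compound 4: 2-(dimethylamino)ethyl on the aromatic nitrogen

The source may hold more compounds than are shown below. What is called first, only, known or untested is meant among the compounds shown, and "the series" means these compounds.

In a functional assay on TSGH cells (Homo sapiens) for inhibition, with a stated time of 72 h (on this read-out lower numbers stand for stronger inhibition and higher numbers for weaker inhibition), compound 1 `COc1cc(C(=O)c2ccc3[nH]ccc3c2)cc(OC)c1OC` gives 103 nM and so holds the middle place among the three measured numbers. Compound 3 `COc1cc(C(=O)c2ccc3c(ccn3CO)c2)cc(OC)c1OC` lies lower at 43 nM and compound 2 `CCCn1ccc2cc(C(=O)c3cc(OC)c(OC)c(OC)c3)ccc21` lies higher at 1500 nM in the same test.

Compound 4 `COc1cc(C(=O)c2ccc3c(ccn3CCN(C)C)c2)cc(OC)c1OC` has not yet been measured. It differs from compound 1 by 2-(dimethylamino)ethyl in place of hydrogen on an aromatic nitrogen.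

Two measured steps change that same nitrogen, and they point in opposite directions. Propyl there gave a 15-fold higher number from compound 1 to compound 2 (1.16 log units; beyond the scatter), while hydroxymethyl gave a 2.4-fold lower number from compound 1 to compound 3 (0.38 log units; beyond the scatter). The gap between these two groups is itself wide, at a 35-fold lower number from compound 2 to compound 3 (1.54 log units; beyond the scatter), so the outcome at this nitrogen varies strongly with the group. Neither is a close match for the new group, which has a carbon chain like propyl but, unlike propyl, also holds a nitrogen.

On that thin basis, a rise is expected, though a smaller one than the propyl step of a 15-fold higher number from compound 1 to compound 2 (1.16 log units; beyond the scatter) in compound 2. The expected size is a 3.4-fold higher number from compound 1 to compound 4 (0.53 log units; beyond the scatter), with real uncertainty in direction. In this assay the estimate for compound 4 is 350 nM, with an expected range from 70 nM to 1800 nM.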

Compound 4, half-maximal inhibitory concentration: 4900 nM
The estimate for compound 4 lay 14-fold (1.15 log units) below the measured number, and the stated range ends below it.
By their numbers in this assay, from the lowest: compound 3; then compound 1; then compound 2; then compound 4.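

In this assay, 2-(dimethylamino)ethyl on the aromatic nitrogen brings the largest rise seen so far at this position, a 48-fold higher number from compound 1 to compound 4 (1.68 log units; beyond the scatter), exceeding the propyl step of a 15-fold higher number from compound 1 to compound 2 (1.16 log units; beyond the scatter). A nitrogen in the chain therefore gives no relief from the loss seen with propyl: dimethylamino in place of the chain-end methyl adds a 3.3-fold higher number from compound 2 to compound 4 (0.51 log units; beyond the scatter), and the difference from the hydroxymethyl compound reaches a 110-fold higher number from compound 3 to compound 4 (2.06 log units; beyond the scatter), making compound 4 the weakest of the four in this test. Nothing available here accounts for these differences.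

The compounds shown leave open whether the lower number of compound 3 goes with its hydroxy group or its short chain, a question that methyl and 2-hydroxyethyl on the same nitrogen would help separate. They also leave open whether the rise in compound 4 is specific to dimethylamino, or would also appear with a primary amine, a morpholine ring or a carboxylic acid at the end of the same chain.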